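Chlorophenyl for Methoxyphenyl: An Expected Growth-Inhibition Value

The compounds below may be only part of what the source reports. "The series", "measured", "known", "first", "only" and "open" are said of these compounds alone.

In a functional assay on U-251 cells (Homo sapiens) for inhibition, read by sulforhodamine B assay, with a stated time of 48 h (on this read-out higher numbers stand for weaker inhibition of growth and lower numbers for stronger inhibition of growth), compound 2 `COc1ccc(/C=N/NC(=S)NC(C)(C)[C@H]2CC=C(C)CC2)cc1` gives 11400 nM, the higher of the two numbers measured here; compound 1 `CC1=CC[C@H](C(C)(C)NC(=S)NN)CC1` gives 200 nM, a far lower number. Compound 3 `CC1=CC[C@H](C(C)(C)NC(=S)N/N=C/c2ccccc2Cl)CC1` keeps everything of compound 2 except one group: 2-chlorophenyl in place of 4-methoxyphenyl on a carbon with a double bond to nitrogen. For the measured compounds named here, no step between measured compounds shows what such a swap does, so the data set no direction. Both groups carry one six-membered aromatic ring, and the step from compound 2 to compound 3 is expected to be small, a 1.4-fold lower number from compound 2 to compound 3 (0.15 log units; within the scatter), likely within the scatter. Compound 3 is therefore estimated at 8000 nM, with a range from 2500 nM to 25000 nM.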

Compound 3, concentration for 50% growth inhibition: 80600 nM
The estimate for compound 3 lay 10-fold (1.00 log units) below the measured number; measured number outside the range, above it.
By their numbers in this assay, from the lowest: compound 1; then compound 2; then compound 3.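

For the compounds shown here, the first step at this position shows that the group on the carbon with a double bond to nitrogen matters: 2-chlorophenyl in place of 4-methoxyphenyl gives a 7.1-fold higher number from compound 2 to compound 3 (0.85 log units; beyond the scatter) in this assay, meaning weaker inhibition of growth. Both groups carry one six-membered aromatic ring, so that shared ring alone does not keep the activity level. Nothing measured here explains this difference.

This single swap changes both the substituent and its printed ring position, so their contributions cannot be separated. As far as these compounds go, how 4-chlorophenyl, unsubstituted phenyl or a ring bearing an amine would behave remains open.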